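Solubility outlook for a hydroxymethyl analogue of compound 2

A few compounds are considered here, and "the series" means these few. Any claim that something is new, unique, unknown or untested is made for them only; others in the source may bear on it.

The compounds measured so far are:
compound 1, `Cc1nccn1-c1cnc(NCc2c(F)ccc3c2CCO3)c2cn[nH]c(=O)c12`, 7000 nM in a physicochemical assay for solubility, read by LC-MS, in phosphate buffer, with a stated time of 24 h, at pH 7.4; on this read-out higher numbers stand for higher solubility and lower numbers for lower solubility;
compound 2, `CNC(=O)c1ccc(-c2cnc(NCc3c(F)ccc4c3CCO4)c3cn[nH]c(=O)c23)c(C)n1`, 19000 nM;
compound 3, `CN(C(=O)c1ccccc1)c1cnc(NCc2c(F)ccc3c2CCO3)n2cnnc12`, 280000 nM.

Among these three numbers compound 2 stands second highest: its nearest neighbour is compound 1, and the only step recorded between two compounds that differ in one place is a 2.7-fold higher number from compound 1 to compound 2 (0.43 log units; beyond the scatter). Among the compounds with values here, compound 3 shows a far higher number than compound 2, but the two differ in more than one place, so no single step is drawn between them.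

The new compound 4, `Cc1nc(CO)ccc1-c1cnc(NCc2c(F)ccc3c2CCO3)c2cn[nH]c(=O)c12`, differs from compound 2 by hydroxymethyl in place of methylcarbamoyl on an aromatic carbon. Within the data shown here, no measured step touches this exact change: the one recorded step concerns the whole ring attached at that position rather than a group on it, so it offers only a loose guide. On that basis compound 4 is expected to stay close to compound 2, with a step of a 1.1-fold higher number from compound 2 to compound 4 (0.02 log units; within the scatter) that need not exceed the scatter. Compound 4 is therefore estimated at 20000 nM, within a range from 7000 nM to 55000 nM.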

Compound 4, solubility: 3000 nM
Compound 4: middle estimate off by 6.7-fold (0.82 log units), on the high side; the whole stated range lies above it.
By their numbers in this assay, from the lowest: compound 4; then compound 1; then compound 2; then compound 3.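

The result shows that the place next to the ring nitrogen, para to a large group, matters in this assay: hydroxymethyl in place of methylcarbamoyl brings a 6.3-fold lower number from compound 2 to compound 4 (0.80 log units; beyond the scatter) even though the two groups have equal counts of hydrogen-bond donors and acceptors. Within the data shown here, the earlier compounds showed only one exchange of the whole group on the shared core, with 2-methyl-6-(methylcarbamoyl)pyridin-3-yl standing higher than 2-methyl-1H-imidazol-1-yl. With 6-(hydroxymethyl)-2-methylpyridin-3-yl the order reverses, giving a 2.3-fold lower number from compound 1 to compound 4 (0.37 log units; beyond the scatter) so that the direction of this exchange depends on what the ring carries, and no measurement offered here explains why. From the compounds shown here alone, whether an amine, a carboxylic acid or a longer chain at this place would stand nearer compound 2 or compound 4 remains open. Also open, going by these compounds, is whether this exchange would give a similar step on the core of compound 3.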